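This account rests on a few compounds, and the source may have more. Where it says the series, first, only, none or still open, it means among the compounds named here.

Measured so far in an assay on blood for inhibition of Polyunsaturated fatty acid 5-lipoxygenase (Homo sapiens), tested at 10 uM; on this read-out higher numbers stand for a stronger effect at the one concentration tested and lower numbers for a weaker effect:

- compound 1, `O=C1OC(c2ccc(OCc3ccccc3)cc2)C(c2ccc(F)cc2)=C1O`: 0%
- compound 2, `O=C1OC(c2cc(OCc3ccccc3)cc(OCc3ccccc3)c2)C(c2ccc(F)cc2)=C1O`: 0%
- compound 3, `O=C1OC(c2ccc(OCc3ccccc3)c(OCc3ccccc3)c2)C(c2ccc(F)cc2)=C1O`: 0%

All three share one core and differ only in how many benzyloxy groups sit on the aryl ring attached to the lactone. Within the data shown here, the one measured step, benzyloxy in place of hydrogen on an aromatic carbon, gives no change at the digits printed from compound 1 to compound 3 (within the scatter). Compound 2 stands level with compound 1 and compound 3, with none of the three rising above the bottom of the read-out in this assay.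

Compound 4, `O=C1OC(c2cc(OCc3ccccc3)cc(OCc3ccccc3)c2)C(c2ccc(O)cc2)=C1O`, keeps the two benzyloxy groups of compound 2 and changes the other aryl ring: hydroxy in place of fluoro on an aromatic carbon. Among the measured compounds shown here, no measured pair covers hydroxy in place of fluoro, so the only guide is that the one measured change left the read-out unmoved, and that every measured compound sits at the same low value. On that basis no step beyond the scatter is expected, a number 5 percentage points higher from compound 2 to compound 4 (within the scatter), and compound 4 is estimated at 5%, within 0% to 25%.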

Compound 4, a percentage reported as activity, at one concentration (the size of the read-out at that concentration, not a potency): 32%
Beside the measured number, compound 4's estimate is 27 percentage points below it; measured number outside the range, above it.
By their numbers in this assay, from the lowest: compounds 1, 2 and 3 (each within the scatter of the next); then compound 4.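

Replacing fluoro with hydroxy, which turns 4-fluorophenyl into 4-hydroxyphenyl, gives a number 32 percentage points higher from compound 2 to compound 4 (beyond the scatter) in this assay. Among these compounds, the earlier compounds differed only in their benzyloxy groups on the other aryl ring and all stayed level, so this is the first sign that the read-out can leave the bottom, and that the group on this ring can matter, at least with the benzyloxy pattern of compound 2. Nothing measured here gives a reason for the rise.

As far as these compounds go, it remains open whether hydroxy is special at this place, or whether a methoxy, an amine or a carboxylic acid there would lift the read-out as well. From the compounds shown here alone, it is also open whether the same swap would raise compound 1 or compound 3, which carry their benzyloxy groups differently.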